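Aryl swap on the chain: trifluorophenyl in place of chloro-trifluoromethylphenyl

This account rests on a few compounds, and the source may have more. Where it says the series, first, only, none or still open, it means among the compounds named here.

Two compounds have been run in a functional assay on CHO cells for antagonist activity at Orexin receptor type 2 (Homo sapiens), read by FLIPR and calcium flux; a lower number here means a stronger inhibitor, a higher number a weaker inhibitor. Compound 1 `CCc1nc(Cl)c2n1CCN([C@@H](C(=O)NC)c1ccccc1)[C@H]2CCc1cccc(C(F)(F)F)c1` gives 10 nM in this assay. Going by the values given here, compound 2 `CCc1nc(Cl)c2n1CCN([C@@H](C(=O)NC)c1ccccc1)[C@H]2CCc1ccc(C(F)(F)F)c(Cl)c1` gives 18 nM in this assay, the higher of the two numbers, with compound 1 as its only neighbour; the step of a 1.8-fold higher number from compound 1 to compound 2 (0.26 log units; within the scatter) lies within the scatter, so no order between the two is claimed. Compound 3 `CCc1nc(Cl)c2n1CCN([C@@H](C(=O)NC)c1ccccc1)[C@H]2CCc1ccc(F)c(F)c1F` is not yet measured. It differs from compound 2 by 2,3,4-trifluorophenyl in place of 3-chloro-4-(trifluoromethyl)phenyl on a saturated chain carbon, two bonds along the chain from a saturated ring carbon. Among the compounds with values here, the only measured step that bears on this position is the one from compound 1 to compound 2, which changed the substitution on the same aryl group and stayed within the scatter. On that basis, for compound 3 a step of a 1.4-fold higher number from compound 2 to compound 3 (0.14 log units; within the scatter) is expected, with no clear direction beyond the scatter. Compound 3 is therefore estimated at 25 nM in this assay, in the range 8 nM to 80 nM.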

Compound 3, half-maximal inhibitory concentration: 5 nM
Compound 3: middle estimate off by 5.0-fold (0.70 log units), on the high side; the whole stated range lies above it.
By their numbers in this assay, from the lowest: compounds 3, 1 and 2 (each within the scatter of the next, the first and the last beyond it).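

In this assay, this position on the chain now shows a step beyond the scatter: 2,3,4-trifluorophenyl in place of 3-chloro-4-(trifluoromethyl)phenyl gives a 3.6-fold lower number from compound 2 to compound 3 (0.56 log units; beyond the scatter), which the earlier pair did not show. Against the 3-(trifluoromethyl)phenyl group, the same entering group gives a 2.0-fold lower number from compound 1 to compound 3 (0.30 log units; within the scatter), so no order is claimed there and the separation holds only against compound 2. No measurement at hand gives a cause for the step.

The compounds shown leave open whether the separation belongs to the full 2,3,4-trifluoro pattern or would persist with a single fluorine, as in 4-fluorophenyl. They also leave open how this position responds to an aryl group carrying an amine or a carboxylic acid, or to a longer chain.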